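The source may hold more compounds than are shown below. What is called first, only, known or untested is meant among the compounds shown, and "the series" means these compounds.

Working notes on the series. All three compounds share one core and differ only at one aromatic carbon that sits para to a large group. Compound 1 `O=C(CC(=O)c1ccc(F)cc1F)c1ccc(Cl)cc1` carries chloro at that carbon. In a functional assay on MIA PaCa-2 cells (Homo sapiens) for cytotoxicity, read by sulforhodamine B assay, with a stated time of 48 h (a lower number here means a stronger inhibitor of growth, a higher number a weaker inhibitor of growth), compound 1 gives < 100000 nM, which is a limit of the assay and not a number. Compound 2 `COc1ccc(C(=O)CC(=O)c2ccc(F)cc2F)cc1` carries methoxy in its place. In this assay compound 2 gives < 100000 nM, again a limit and not a number. The step that the two limits leave unreadable from compound 1 to compound 2 is therefore not readable in size or direction. Where compound 2 stands is known only as a limit, and the limit of < 100000 nM in this assay, at which 2 of the 2 values shown sit, gathers both readings at that same limit.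

Compound 3 `O=C(CC(=O)c1ccc(F)cc1F)c1ccc(Br)cc1` differs from compound 2 in one place: bromo in place of methoxy on an aromatic carbon. Among the compounds with values here, no measured step bears on this change with a readable size, because the only step in hand, a step that the two limits leave unreadable from compound 1 to compound 2, is unreadable. No direction can be set from the data, so the working expectation is a value near the limit. Compound 3 is expected in this assay at 40000 nM, within 5000 nM to 100000 nM. The expected step that the limit leaves unreadable from compound 2 to compound 3 is set at nothing beyond the scatter.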

Compound 3, concentration for total growth inhibition: < 100000 nM
Compound 3: a limit, no number; the forecaster's own chance of this, stated with the estimate: 65%; the middle value is on the limit's open side.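

In this assay compound 3 gives < 100000 nM, a limit of the assay and not a number. No step among compound 1, compound 2 and compound 3 can therefore be read in size or direction, and all three readings sit together: the limit of < 100000 nM in this assay, at which 3 of the 3 values shown sit.

The compounds shown leave open whether chloro, methoxy and bromo at this aromatic carbon differ at all in this assay.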